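The compounds below may be only part of what the source reports. "The series", "measured", "known", "first", "only" and "open" are said of these compounds alone.

Measured in a functional assay on HCT-116 cells (Homo sapiens) for cytotoxicity, read by MTT assay, with a stated time of 72 h; a higher number here means a weaker inhibitor, a lower number a stronger inhibitor:

- Compound 1 `O=C(NCc1ccc(F)cc1)c1nc(Br)c2cccnc2c1NCCCNc1c(C(=O)NCc2ccc(F)cc2)nc(Br)c2cccnc12`: > 20000 nM, a limit of the assay and not a number
- Compound 2 `C[C@@H](Nc1c(C(=O)NCc2ccc(F)cc2)nc(Br)c2cccnc12)c1ccccc1`: > 20000 nM, also a limit and not a number
- Compound 3 `NCCCNc1c(C(=O)NCc2ccc(F)cc2)nc(Br)c2cccnc12`: 18000 nM

Going by the values given here, compound 3 stands alone in one respect: its 18000 nM is the only true number in this small set, so it cannot be ranked firmly against the other two. The evidence here is thin, and the limit of > 20000 nM in this assay, at which 2 of the 3 values shown sit, is the main feature of the data.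

Compound 4 `CN(C)CCCNc1c(C(=O)NCc2ccc(F)cc2)nc(Br)c2cccnc12` keeps everything in compound 3 except the end of its chain: dimethylamino in place of amino on a saturated chain carbon, three bonds along the chain from a nitrogen on an aromatic ring. In words, this is dimethylamino in place of amino on a saturated chain carbon, three bonds along the chain from a nitrogen on an aromatic ring.

Among the compounds with values here, only one measured step bears on this, and only loosely. It is an at least 1.1-fold lower number from compound 2 to compound 3 (0.04 log units; that floor lies within the scatter), a different swap on the same nitrogen, with 3-aminopropyl in place of 1-phenylethyl. Within the data shown here, no measured step tests a change at the chain end itself, so the expectation stays close to compound 3, and a report of only a limit would be no surprise.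

The expected change is a 1.3-fold lower number from compound 3 to compound 4 (0.11 log units; within the scatter), which stays within the usual scatter. The estimate for compound 4 is 14000 nM, with an expected range from 5000 nM to 28000 nM.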

Compound 4, half-maximal inhibitory concentration: > 10000 nM
Compound 4: only a limit was reported; the forecaster's own chance of this, stated with the estimate: 35%; the middle value lies beyond the limit too.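

Compound 4 gives > 10000 nM, which is a limit of the assay and not a number. The steps to compound 4 from compound 3 and from compound 2 cannot be read. Going by these compounds, it remains open whether 3-(dimethylamino)propyl in place of 3-aminopropyl changes the cytotoxicity number at all, and in which direction.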